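This account rests on a few compounds, and the source may have more. Where it says the series, first, only, none or still open, it means among the compounds named here.

Measured so far:
compound 1 `CCC(/C=C1\OC(=O)NC1=O)(CC)c1ccc(-c2ccc3cc(F)cc(F)c3c2)[nH]c1=O` — 28 nM
compound 2 `C/C(=C1/OC(=O)NC1=O)C(c1ccc(-c2ccc3cccc(F)c3c2)[nH]c1=O)C(C)C` — 17 nM

In an assay on membranes from Chem-1 cells for displacement of a labelled ligand from prostaglandin E2 receptor EP3 subtype (Homo sapiens), read by scintillation counting, with a stated time of 2 h (a higher number here means a weaker inhibitor, a lower number a stronger inhibitor), compound 2 gives 17 nM, the lower of the two numbers shown. Compound 1 gives 28 nM, and that gap is within the scatter, so no ranking between them is warranted. Compound 3 `CC(C)C(/C=C1/C(=O)NC(=O)N1C)c1ccc(-c2ccc3cccc(F)c3c2)[nH]c1=O` is not yet measured. It differs from compound 2 by a group of 9 heavy atoms (5 carbon, 2 nitrogen, 2 oxygen; one five-membered non-aromatic ring with 2 hetero atoms) in place of a group of 9 heavy atoms (5 carbon, 1 nitrogen, 3 oxygen; one five-membered non-aromatic ring with 2 hetero atoms), on a saturated chain carbon bound to an aromatic carbon and a saturated chain carbon. Going by the values given here, no measured pair covers a change of this kind, so the direction is open; a modest loss is the nearer guess, but a shift beyond the scatter either way cannot be excluded. The number expected for compound 3 in this assay is 35 nM, within 8 nM to 150 nM, an expected step of a 2.1-fold higher number from compound 2 to compound 3 (0.31 log units; beyond the scatter).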

Compound 3, inhibition constant: 6 nM
Estimate against measurement, compound 3: 5.8-fold (0.77 log units) above, and the stated range ends above it.
By their numbers in this assay, from the lowest: compound 3; then compounds 2 and 1 (each within the scatter of the next).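

Exchanging the group of 5 carbon, 1 nitrogen and 3 oxygen for the group of 5 carbon, 2 nitrogen and 2 oxygen on this saturated chain carbon gives a 2.8-fold lower number from compound 2 to compound 3 (0.45 log units; beyond the scatter) in this assay. Going by these compounds alone, this is the first single-place comparison: the five-membered non-aromatic ring group can change at equal heavy-atom count, with hydrogen-bond acceptors going from 3 to 2, and affinity still improves modestly. Nothing available bears on the cause of this shift. As far as these compounds go, whether the same exchange holds on the core of compound 1 remains open. Also open, from the compounds shown here alone, is how a carboxylic acid or an amine would fare in place of this ring group on the same carbon.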